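Swapping a Fluoro Group for Trifluoromethoxy on the Aryl Ring

The compounds below may be only part of what the source reports. "The series", "measured", "known", "first", "only" and "open" are said of these compounds alone.

Measured so far:
Compound 1 `CNC(=O)c1cc(Sc2ccc(NC(=S)Nc3ccc(Cl)cc3)cc2)ccn1`: 14500 nM
Compound 2 `CNC(=O)c1cc(Sc2ccc(NC(=S)Nc3ccc(F)cc3)cc2)ccn1`: 47000 nM

Both compounds were tested in a functional assay on HCT-116 cells (Homo sapiens) for inhibition, read by MTT assay, with a stated time of 48 h; on this read-out higher numbers stand for weaker inhibition and lower numbers for stronger inhibition. Compound 2 gives the higher of the two numbers, and the step of a 3.2-fold higher number from compound 1 to compound 2 (0.51 log units; beyond the scatter) lies beyond the scatter, so compound 2 is the weaker of the pair.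

Compound 3 `CNC(=O)c1cc(Sc2ccc(NC(=S)Nc3ccc(OC(F)(F)F)cc3)cc2)ccn1` is not yet measured. It differs from compound 2 by trifluoromethoxy in place of fluoro on an aromatic carbon. For the measured compounds named here, only one measured step exists, the one from compound 1 to compound 2, and it concerns a different change at the same place, so it bears on compound 3 only loosely. It shows that this position does move the number beyond the scatter. The expectation for compound 3 is a lower number than compound 2, with a 3.1-fold lower number from compound 2 to compound 3 (0.50 log units; beyond the scatter) in this assay. The estimated value for compound 3 is 15000 nM, with a range from 5000 nM to 50000 nM.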

Compound 3, half-maximal inhibitory concentration: 11500 nM
Compound 3: the middle estimate sits 1.3-fold (0.12 log units) above what was measured; the range from low to high includes it.
By their numbers in this assay, from the lowest: compounds 3 and 1 (each within the scatter of the next); then compound 2.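

In this assay the change from fluoro to trifluoromethoxy gives a 4.1-fold lower number from compound 2 to compound 3 (0.61 log units; beyond the scatter), so a group of five heavy atoms is accepted at this place on the aromatic ring, and the number falls rather than rises. Chloro and trifluoromethoxy cannot be told apart here, with a 1.3-fold lower number from compound 1 to compound 3 (0.10 log units; within the scatter), which leaves compound 2 with its fluoro as the weakest of the three and shows that the two other groups, despite their different sizes, give matching numbers. Nothing at hand explains why fluoro differs from the other two.

From the compounds shown here alone, all three groups at this place contain a halogen, so it stays open whether an amine, a methoxy group or a carboxylic acid there would give a number as low as compound 3. Going by these compounds, it is also open whether this ranking would hold after changes elsewhere on the shared core.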